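Nitro-to-methyl swap on a second methoxy core

The source may hold more compounds than are shown below. What is called first, only, known or untested is meant among the compounds shown, and "the series" means these compounds.

Measured compounds:
compound 1, `CCOC(=O)c1c(-c2cccc(C)c2)[nH]c2cc(OC)ccc2c1=O`, 48000 nM
compound 2, `CCOC(=O)c1c(-c2cccc([N+](=O)[O-])c2)[nH]c2cc(OC)ccc2c1=O`, 13000 nM
compound 3, `CCOC(=O)c1c(-c2cccc([N+](=O)[O-])c2)[nH]c2cccc(OC)c2c1=O`, 49000 nM

In a physicochemical assay for solubility, in phosphate buffer, at pH 7.4 (on this read-out higher numbers stand for higher solubility and lower numbers for lower solubility), compound 2 gives 13000 nM and compound 1 gives 48000 nM. The two share a core and differ only in one place: methyl in place of nitro on an aromatic carbon. That change made a step of a 3.7-fold higher number from compound 2 to compound 1 (0.57 log units; beyond the scatter).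

Compound 3 carries the same nitro group as compound 2 on a core that differs from it; the difference between the two cores is not broken down here. In this assay compound 3 gives 49000 nM, which lies within the scatter of the number for compound 1 and is higher than the number for compound 2.

Compound 4, `CCOC(=O)c1c(-c2cccc(C)c2)[nH]c2cccc(OC)c2c1=O`, is not yet measured. It stands to compound 3 as compound 1 stands to compound 2: methyl in place of nitro on an aromatic carbon. The place of the change is the same in both pairs, so this is the same change, seen here for the second time.

Expectation: the step from compound 3 to compound 4 in this assay is estimated at a 3.1-fold higher number from compound 3 to compound 4 (0.49 log units; beyond the scatter), resting on the single earlier instance, the step of a 3.7-fold higher number from compound 2 to compound 1 (0.57 log units; beyond the scatter). Since that earlier step was measured on a different core, and only once, the range is kept wide. Compound 4 is expected to give about 150000 nM, between 60000 nM and 400000 nM.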

Compound 4, solubility: > 100000 nM
Compound 4: a limit, no number; the forecaster's own chance of this, stated with the estimate: 5%; the middle value lies beyond the limit too.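

In this assay compound 4 gives > 100000 nM, which is a limit of the assay and not a number. Methyl in place of nitro on an aromatic carbon now gives an at least 2.0-fold higher number from compound 3 to compound 4 (0.30 log units; that floor lies within the scatter) on the one core, against a 3.7-fold higher number from compound 2 to compound 1 (0.57 log units; beyond the scatter) on the other, so the two pairs agree in direction, though the new step is only a floor and does not by itself stand clear of the scatter. What the new pair does not show is whether the change keeps its size from one core to the other, because the upper reading of that pair is no number: the limit of > 100000 nM in this assay, at which 1 of the 4 values shown sits.

The compounds shown leave open how an amine or a carboxylic acid in place of the nitro or the methyl would read in this assay, on either core. Within the data shown here, with only two pairs in hand, they also leave open whether the step would hold on a third core, and how a longer chain in place of the methyl would behave.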